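Furan-2-yl Replacing 4-Chlorophenyl: Notes on Compound 4

This account rests on a few compounds, and the source may have more. Where it says the series, first, only, none or still open, it means among the compounds named here.

Compound 3 `O=C(Nn1c(-c2cccc([N+](=O)[O-])c2)nc2c(-c3ccc(Cl)cc3)n[nH]c2c1=O)c1ccccc1` stands highest of the three numbers in a functional assay on DU-145 cells (Homo sapiens) for cytotoxicity, read by sulforhodamine B assay, with a stated time of 2 days, tested at 100 uM (a higher number here means more inhibition at the concentration tested (going by the name of the read-out), a lower number less inhibition), giving 94.3%. Compound 2 `O=C(Nn1c(-c2cccc([N+](=O)[O-])c2)nc2c(-c3cccc(Cl)c3)n[nH]c2c1=O)c1ccccc1` gives 93.8%, and the step of a number 0.5 percentage points higher from compound 2 to compound 3 (within the scatter) lies within the scatter. Compound 1 `O=C(Nn1c(-c2cccc([N+](=O)[O-])c2)nc2c(-c3ccco3)n[nH]c2c1=O)c1cccnc1` gives 1.66%, far beneath both.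

Compound 4 `O=C(Nn1c(-c2cccc([N+](=O)[O-])c2)nc2c(-c3ccco3)n[nH]c2c1=O)c1ccccc1` is reached from compound 3 by furan-2-yl in place of 4-chlorophenyl on an aromatic carbon. For the measured compounds named here, no measured step covers this exchange directly. Going by the values given here, the only measured step, from compound 2 to compound 3, is a chlorine shift on the phenyl and says nothing about the furan. Compound 1 carries the same furan-2-yl as compound 4 but a pyridine carbonyl amide instead of the benzoyl amide, so its low value cannot be ascribed to either part alone; both compounds 2 and 3, with chlorophenyl and benzoyl, sit high.

A downward step a number 59.3 percentage points lower from compound 3 to compound 4 (beyond the scatter) beyond the scatter is therefore expected, of uncertain depth, because compound 1 with the furan gives 1.66%. For compound 4 the estimate in this assay is 35%, with a range from 3% to 90%.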

Compound 4, a percentage reported as inhibition, at one concentration (the size of the read-out at that concentration, not a potency): 16.1%
Compound 4: the middle estimate sits 18.9 percentage points above what was measured, and the stated range covers the measured number.
By their numbers in this assay, from the lowest: compound 1; then compound 4; then compounds 2 and 3 (each within the scatter of the next).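

In this assay, the furan-2-yl exchange at this aromatic carbon now has a direct reading: a number 78.2 percentage points lower from compound 3 to compound 4 (beyond the scatter), and a number 77.7 percentage points lower from compound 2 to compound 4 (beyond the scatter), so the large drop appears against both chlorophenyl groups. With furan-2-yl held in place, the amide side can also be read on its own: a number 14.4 percentage points higher from compound 1 to compound 4 (beyond the scatter), a modest step beside those at the ring carbon. Nothing available explains either step.

The compounds shown leave open whether the drop belongs to furan-2-yl itself or to the absence of chlorophenyl, and a plain phenyl, a methyl or an amine at this carbon would bear on that. Also open, from the compounds shown here alone, is whether phenyl in place of pyridin-3-yl on the carbonyl carbon gives a step of similar size when a chlorophenyl group sits at the ring carbon.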